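Trifluoromethyl for Methyl: Expected Efficacy of Compound 3

The source may report more compounds than this note shows. Statements on the series, on what has been measured and on what is new or still open speak of the compounds shown alone.

Measured compounds:
compound 1, `O=C(CN1CCC(c2cccc[n+]2[O-])CC1)Nc1ccc(F)cc1`, 71%
compound 2, `Cc1cc(F)ccc1NC(=O)CN1CCC(c2cccc[n+]2[O-])CC1`, 84%

In a functional assay on HEK293 cells for agonist activity at D(4) dopamine receptor (Homo sapiens), read by FLIPR (on this read-out lower numbers stand for smaller maximal responses and higher numbers for larger maximal responses), compound 1 gives 71%, and compound 2 gives 84%. Compound 2 thus holds the higher of the two numbers, with a number 13 percentage points higher from compound 1 to compound 2 (beyond the scatter).

Compound 3 is `O=C(CN1CCC(c2cccc[n+]2[O-])CC1)Nc1ccc(F)cc1C(F)(F)F`. Its change from compound 2 is trifluoromethyl in place of methyl on an aromatic carbon. Going by the values given here, the only measured step that touches this aromatic carbon is a number 13 percentage points higher from compound 1 to compound 2 (beyond the scatter), which shows that a substituent at this position can move the maximal response by a modest amount. Among the compounds with values here, no measured pair shows what trifluoromethyl does in place of methyl, so the direction of the step in this assay cannot be taken from the data; the one step seen argues that this position tolerates substitution and that compound 3 should not fall far below compound 2. The expected step is therefore a number 4 percentage points lower from compound 2 to compound 3 (within the scatter), within the scatter around compound 2. Compound 3 is accordingly estimated at 80%, with a range from 62% to 96%.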

Compound 3, largest response reached (reported as efficacy), in percent of the reference or control that the assay uses: 65%
For compound 3 the middle estimate is 15 percentage points above the measured one, and the stated range covers the measured number.
By their numbers in this assay, from the lowest: compounds 3 and 1 (each within the scatter of the next); then compound 2.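

In this assay, trifluoromethyl in place of methyl on this aromatic carbon gives a number 19 percentage points lower from compound 2 to compound 3 (beyond the scatter), so the position does not treat these two groups alike, and the tolerance suggested by the first pair does not extend to every substituent. Trifluoromethyl in place of hydrogen on the same carbon gives a number 6 percentage points lower from compound 1 to compound 3 (within the scatter), whereas methyl in place of hydrogen gives a number 13 percentage points higher from compound 1 to compound 2 (beyond the scatter), so the gain belongs to methyl among the groups shown and not to substitution at this carbon as such. No measurement on hand bears on why the maximal response depends on the group here.

Going by these compounds, what remains open is whether a chlorine atom, a methoxy group or an ethyl chain on this aromatic carbon would keep the maximal response near that of compound 2, at 84%, or leave it closer to the unsubstituted compound 1, at 71%. Also open, on these data alone, is whether the step seen with methyl survives a change to the fluoro group or to the shared core, as all three compounds carry both.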